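The compounds below may be only part of what the source reports. "The series", "measured", "known", "first", "only" and "open" are said of these compounds alone.

Measured compounds:
- compound 1, `Cc1ccnc(/C(N)=N/NC(=S)N2CCSCC2)c1`: 41.1%
- compound 2, `N/C(=N\NC(=S)N1CCSCC1)c1ccccn1`: 25.1%

The read-out throughout is a functional assay on HeLa cells (Homo sapiens) for cytotoxicity, read by MTT assay, with a stated time of 72 h, tested at 1 uM; on this read-out lower numbers stand for less inhibition of growth and higher numbers for more inhibition of growth at the one concentration tested. On this read-out compound 1 gives 41.1%, the higher of the two numbers recorded; compound 2 gives 25.1%. Within the data shown here, the one step measured so far, a number 16 percentage points lower from compound 1 to compound 2 (beyond the scatter), runs through the exchange of a methyl on an aromatic carbon for hydrogen, and it is beyond the scatter.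

Compound 3, `Cc1ccnc(/C(N)=N/NC(=S)N2CCCCC2)c1`, differs from compound 1 at a different spot: piperidin-1-yl in place of thiomorpholin-4-yl on a thiocarbonyl carbon. The methyl on the aromatic ring is kept. Among the measured compounds shown here, no measured step touches this part of the molecule; the only step in hand, the one from compound 1 to compound 2, changes the aromatic ring and says nothing about what replacing sulfur in the saturated ring by carbon does. In this assay the expectation therefore rests on the parent compound alone, with a step of a number 3.1 percentage points lower from compound 1 to compound 3 (within the scatter) that is expected to stay within the scatter. For compound 3 the estimated value in this assay is 38%, with a range from 18% to 58%.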

Compound 3, percent growth inhibition at one concentration: 15.3%
Beside the measured number, compound 3's estimate is 22.7 percentage points above it; the measured number lies below the stated range.
By their numbers in this assay, from the lowest: compounds 3 and 2 (each within the scatter of the next); then compound 1.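

In this assay, exchanging thiomorpholin-4-yl for piperidin-1-yl on the thiocarbonyl carbon, with the methyl on the aromatic ring kept, gives a number 25.8 percentage points lower from compound 1 to compound 3 (beyond the scatter) in this comparison, even though both groups are six-membered non-aromatic rings of the same heavy-atom count, with sulfur exchanged for carbon. The earlier pair, through a number 16 percentage points lower from compound 1 to compound 2 (beyond the scatter) as its step, spoke only to the methyl on the aromatic ring; the new step shows that the group on the thiocarbonyl carbon is a second place where one change moves the number beyond the scatter. Nothing measured here accounts for this difference between the two rings.

The compounds shown leave open whether sulfur is specifically tied to the higher number or whether another ring atom would do the same, as the oxygen of morpholin-4-yl or the second nitrogen of piperazin-1-yl would test. They also leave open whether an open-chain group such as dimethylamino can stand on the thiocarbonyl carbon, and whether piperidin-1-yl has the same effect on the core lacking the aromatic methyl.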